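The source may report more compounds than this note shows. Statements on the series, on what has been measured and on what is new or still open speak of the compounds shown alone.

Compound 1 `Nc1cc(N)c2nc(-c3ccccc3)c(Sc3ccc(F)cc3)nc2c1` was tested in a functional assay on HT-29 cells (Homo sapiens) for inhibition, read by sulforhodamine B assay, with a stated time of 48 h (on this read-out higher numbers stand for weaker inhibition of growth and lower numbers for stronger inhibition of growth), where compound 1 gives 17800 nM. Among the numbers recorded, this is the higher of the two: compound 2 `COc1cc(CNc2nc3cc(N)cc(N)c3nc2-c2ccccc2)cc(OC)c1OC` gives 8710 nM in this assay, a lower number, and the gap lies beyond the usual scatter. Compound 3 `CCOC(=O)[C@H](CCC(=O)O)NC(=O)c1ccc(CNc2nc3cc(N)cc(N)c3nc2-c2ccccc2)cc1` reaches only a limit of this assay, < 100000 nM, as noted in the limit of < 100000 nM in this assay, at which 1 of the 3 values shown sits. Compound 4 `Nc1cc(N)c2nc(-c3ccccc3)c(NCc3ccc(F)cc3)nc2c1` has not yet been measured. It differs from compound 1 in one place: (4-fluorobenzyl)amino in place of (4-fluorophenyl)sulfanyl on an aromatic carbon. Since compound 2 also carries an amino-linked benzyl group on the shared core and gives 8710 nM, compound 4 is expected to move in the same direction, with a modest step of a 1.8-fold lower number from compound 1 to compound 4 (0.25 log units; within the scatter). Compound 4 is therefore estimated at 10000 nM, likely between 3000 nM and 35000 nM.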

Compound 4, concentration for 50% growth inhibition: 3160 nM
For compound 4 the middle estimate is 3.2-fold (0.50 log units) above the measured one, within the range that was stated.
By their numbers in this assay, from the lowest: compound 4; then compound 2; then compound 1.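

Within the data shown here, on the aromatic carbon next to the ring nitrogen, (4-fluorobenzyl)amino in place of (4-fluorophenyl)sulfanyl gives a 5.6-fold lower number from compound 1 to compound 4 (0.75 log units; beyond the scatter) in this assay, the first direct reading of a change at this position. Growth inhibition here therefore responds to the group on this carbon, and the entering group carries a hydrogen-bond donor that the leaving group lacks. Nothing measured here explains the step.

The change alters both the linking atom and the linker length, and these two effects remain unseparated. From the compounds shown here alone, a (4-fluorophenyl)amino group or a longer 2-(4-fluorophenyl)ethylamino chain on this carbon remains open.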